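A few compounds are considered here, and "the series" means these few. Any claim that something is new, unique, unknown or untested is made for them only; others in the source may bear on it.

For the measured compounds named here, in an ADME assay on Vero cells (Chlorocebus sabaeus) for cytotoxicity, read by resazurin assay, with a stated time of 24 h (a higher number here means that more compound is tolerated, a lower number that less compound is tolerated), three compounds have numbers so far. Compound 1 `CC(=O)OC[C@H]1O[C@H](OC(C)C)C=CC1=O` gives 104000 nM here, and compound 2 `Cc1ccc(S(=O)(=O)OC[C@H]2O[C@H](OC(C)C)C=CC2=O)cc1` gives 13400 nM here. Compound 3 `CCCCCCO[C@@H]1C=CC(=O)[C@@H](COC(=O)C(C)(C)C)O1` has the lowest number of the three (4800 nM), and its gaps to both others lie beyond the scatter.

Compound 4 `CC(C)(C)C(=O)OC[C@H]1O[C@H](OCC2CC2)C=CC1=O` differs from compound 3 in one place (cyclopropyl in place of pentyl on a saturated chain carbon bound to an oxygen on a saturated carbon), with cyclopropyl in place of pentyl on a saturated chain carbon bound to an oxygen on a saturated carbon. The hexyl thus becomes cyclopropylmethyl. Going by the values given here, no two measured compounds differ in just one place, so no direct step is available as a guide. Compound 2 also lacks the hexyl and stands higher at 13400 nM on this scale, although it differs from compound 3 elsewhere too. A moderate rise beyond the scatter is therefore expected, meaning more compound tolerated. The expected change is a 2.9-fold higher number from compound 3 to compound 4 (0.46 log units; beyond the scatter) on this estimate. The estimate for compound 4 is 14000 nM, with 5500 nM to 40000 nM as its expected range.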

Compound 4, half-maximal cytotoxic concentration: 77200 nM
Compound 4: the middle estimate sits 5.5-fold (0.74 log units) below what was measured; measured number above the stated range.
By their numbers in this assay, from the lowest: compound 3; then compound 2; then compounds 4 and 1 (each within the scatter of the next).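

In this assay, for the compounds shown here, putting cyclopropyl in place of pentyl on a saturated chain carbon bound to an oxygen on a saturated carbon gives a 16-fold higher number from compound 3 to compound 4 (1.21 log units; beyond the scatter) as the first direct reading of a single change in this set. Going by these compounds alone, it shows that this position alone can move the tolerated concentration by a large amount, which the earlier compounds could not show, as they differ from one another in more than one place. Nothing measured here accounts for the size of this step.

This one step cannot separate the shorter chain from the arrival of the ring, so a straight propyl or butyl chain or a larger cyclohexylmethyl group would be needed to tell them apart. As far as these compounds go, whether a terminal amine or carboxylic acid on this chain would be tolerated as well also remains open.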